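This account rests on a few compounds, and the source may have more. Where it says the series, first, only, none or still open, it means among the compounds named here.

The shared core of compound 2 `Cc1cc(Cl)ccc1OCc1nnc(-c2ccccc2F)o1` carries a 2-fluorophenyl. In an ADME assay on cells for inhibition of anoctamin-2 (Homo sapiens), read by fluorescence, with a stated time of 20 min (a higher number here means a weaker inhibitor, a lower number a stronger inhibitor), compound 2 gives > 100000 nM, which is a limit of the assay rather than a number. Compound 3 `Cc1cc(Cl)ccc1OCc1nnc(-c2cccc(F)c2)o1`, the 3-fluorophenyl analogue, gives > 100000 nM in this assay, likewise a limit. The step that the two limits leave unreadable from compound 2 to compound 3 therefore cannot be read. Compound 1 `Cc1cc(Cl)ccc1OC(C)C(=O)N/N=C/c1ccccc1OC(F)(F)F`, built on a different scaffold, is recorded in this assay as "not active" (no number reported), without a number. Compound 4 `COc1ccccc1-c1nnc(COc2ccc(Cl)cc2C)o1` differs from compound 2 by methoxy in place of fluoro on an aromatic carbon. For the measured compounds named here, no measured step reaches past the limit (the limit of > 100000 nM in this assay, at which 2 of the 3 values shown sit), so no readable shift is known for the change leading to compound 4. Compound 4 is therefore expected to sit near the same limit, with a number no higher from compound 2 to compound 4 (the limit leaves the size open) expected to be nil within scatter, and its estimated value is 100000 nM, ranging from 30000 nM to 300000 nM.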

Compound 4, half-maximal inhibitory concentration: 12400 nM
Beside the measured number, compound 4's estimate is 8.1-fold (0.91 log units) above it; the whole stated range lies above it.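

Methoxy in place of fluoro on this aromatic carbon, ortho to a large group, gives the first readable change in this assay, namely an at least 8.0-fold lower number from compound 2 to compound 4 (0.90 log units; beyond the scatter). The number at this position thus responds to the group it carries, which the unreadable step between the 2-fluorophenyl and 3-fluorophenyl compounds could not show. From the compounds shown here alone, compound 2 stands at a limit, so the step's full size stays unknown: the limit of > 100000 nM in this assay, at which 2 of the 4 values shown sit.

The compounds shown leave open whether ethoxy, hydroxyl or an amine on this carbon would lower the number further. They also leave open whether methoxy would have the same effect elsewhere on this ring.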